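A few compounds are considered here, and "the series" means these few. Any claim that something is new, unique, unknown or untested is made for them only; others in the source may bear on it.

Measured compounds:
compound 1 `CC(=O)Nc1ccc2oc(-c3ccccc3)cc(=O)c2c1` — 97000 nM
compound 2 `COc1cccc(-c2cc(=O)c3cc(NC(C)=O)ccc3o2)c1` — 10000 nM
compound 3 `CC(=O)Nc1ccc2oc(-c3cccc(C(F)(F)F)c3)cc(=O)c2c1` — 50000 nM

In an ADME assay on THP-1 cells (Homo sapiens) for cytotoxicity, read by flow cytometry and propidium iodide staining, with a stated time of 72 h (a lower number here means a stronger inhibitor, a higher number a weaker inhibitor), compound 2 stands lowest of the three numbers; the nearest is compound 3, with a 5.0-fold higher number from compound 2 to compound 3 (0.70 log units; beyond the scatter), and the furthest is compound 1, with a 9.7-fold lower number from compound 1 to compound 2 (0.99 log units; beyond the scatter). Compound 4 `COc1cccc(-c2cc(=O)c3cc(N)ccc3o2)c1` keeps everything of compound 2 except one change: hydrogen in place of acetyl on a nitrogen on an aromatic ring. Going by the values given here, no measured step touches that nitrogen; the three measured steps, a 9.7-fold lower number from compound 1 to compound 2 (0.99 log units; beyond the scatter), a 1.9-fold lower number from compound 1 to compound 3 (0.29 log units; within the scatter) and a 5.0-fold higher number from compound 2 to compound 3 (0.70 log units; beyond the scatter), all concern a substituent on the aromatic carbon. Among the compounds with values here, they therefore give no direction for the step from compound 2 to compound 4 in this assay, and no step beyond the scatter is expected. Compound 4 is estimated at 10000 nM, within 3000 nM to 40000 nM, the expected step being no change at the digits printed from compound 2 to compound 4 (within the scatter).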

Compound 4, half-maximal inhibitory concentration: > 125000 nM
Compound 4 gave a limit, no number; the forecaster's own chance of this, stated with the estimate: 10%; middle value at least 12-fold (1.09 log units) from the limit.
By their numbers in this assay, from the lowest: compound 2; then compounds 3 and 1 (each within the scatter of the next). At a limit, above all of these: compound 4.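

In this assay, going by these compounds alone, the nitrogen on the aromatic ring proves to be a place where one change moves the number strongly, which the earlier steps on the aromatic carbon could not show: an at least 12-fold higher number from compound 2 to compound 4 (1.09 log units; beyond the scatter). Compound 4 gives a limit of the assay, not a number: the limit of > 125000 nM in this assay, at which 1 of the 4 values shown sits. As far as these compounds go, the direction of acetamido to amino is therefore clear here, but its full size is unknown.

From the compounds shown here alone, whether the same change acts alike on compound 1 or compound 3 stays open. So does whether a longer acyl chain, a methylsulfonyl or a methyl group on that nitrogen would keep the number of compound 2.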